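The compounds below may be only part of what the source reports. "The series", "measured", "known", "first", "only" and "open" are said of these compounds alone.

Compound 1 `COc1cc(-c2nn(-c3cccc(NC(=O)Nc4cc(C(F)(F)F)cc(C(F)(F)F)c4)c3)cc2-c2ccncc2)ccc1Cl` gives 1040 nM

Compound 2 `COc1cc(-c2nn(-c3cccc(NC(=O)c4cccc(C(F)(F)F)c4)c3)cc2-c2ccncc2)ccc1Cl` gives 1070 nM

Both values come from a functional assay on Hs-578T cells (Homo sapiens) for inhibition, read by sulforhodamine B assay, with a stated time of 48 h (a lower number here means a stronger inhibitor of growth, a higher number a weaker inhibitor of growth), and lie within the usual scatter of each other, so compound 2 stands level with compound 1 on these numbers.

The next structure is compound 3 `COc1cc(-c2nn(-c3cccc(NC(=O)c4ccccc4)c3)cc2-c2ccncc2)ccc1Cl` which has hydrogen in place of trifluoromethyl on an aromatic carbon of compound 2. The site is on a six-membered aromatic ring of carbon only, meta to a large group, so 3-(trifluoromethyl)phenyl becomes phenyl. The count of that change reads hydrogen in place of trifluoromethyl on an aromatic carbon and the rest of the structure stays the same.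

Going by the values given here, no pair of measured compounds differs in this one place, so the data give no direct guide to this step. Both measured compounds carry trifluoromethyl, and none lacks it. A modest move to a higher number, meaning a weaker inhibitor of growth, is therefore expected, though with wide uncertainty. The expected step is a 2.3-fold higher number from compound 2 to compound 3 (0.37 log units; beyond the scatter) in this assay and it remains an estimate. In this assay compound 3 is estimated at 2500 nM with an expected range from 900 nM to 7000 nM until it is measured.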

Compound 3, concentration for 50% growth inhibition: 1110 nM
Compound 3: the middle estimate sits 2.3-fold (0.35 log units) above what was measured, within the range that was stated.
By their numbers in this assay, from the lowest: compounds 1, 2 and 3 (each within the scatter of the next).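

Taking trifluoromethyl off this aromatic carbon, so that 3-(trifluoromethyl)phenyl becomes phenyl, gives the first direct reading at this position: in this assay the step is a 1.0-fold higher number from compound 2 to compound 3 (0.02 log units; within the scatter). In this pair, a group of four heavy atoms can give way to a single hydrogen atom, and the two compounds still stand level in growth inhibition, so compound 3 matches compound 2 without any trifluoromethyl on this ring. No measurement at hand offers an explanation for this, so the result stands as an observation only.

This single pair cannot say whether other groups on the same carbon, such as a methoxy group, an amine or a carboxylic acid, would also stand level with hydrogen or would give a clearly different number. It also leaves open whether the same swap would read the same way with a urea in place of the amide, as in the linker of compound 1.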